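The source may hold more compounds than are shown below. What is called first, only, known or untested is meant among the compounds shown, and "the series" means these compounds.

Compounds measured in an assay on HEK293 cells for inhibition of Voltage-dependent T-type calcium channel subunit alpha-1G (Homo sapiens), read by patch clamp; on this read-out higher numbers stand for weaker inhibition and lower numbers for stronger inhibition:
compound 1 `CCCc1nc(-c2ccccc2)c(CNCCN2CCN(c3cccc(C(F)(F)F)c3)CC2)o1`: 1940 nM
compound 2 `CCCc1nc(-c2ccccc2)c(CNCCN2CCN(c3ccccc3Cl)CC2)o1`: 4370 nM
compound 3 `CCCc1nc(-c2ccccc2)c(CNCCN2CCN(c3ccc(C(F)(F)F)cc3)CC2)o1`: 1300 nM

Among these three, compound 3 has the lowest number in this assay; compound 1 lies within the scatter of it, whereas compound 2 lies beyond it, with a 3.4-fold lower number from compound 2 to compound 3 (0.53 log units; beyond the scatter). Compound 4 `CCCc1nc(-c2ccccc2)c(CNCCN2CCN(c3cccc(Cl)c3)CC2)o1` has not yet been measured. Its change from compound 3 is 3-chlorophenyl in place of 4-(trifluoromethyl)phenyl on an amine nitrogen in a ring. Within the data shown here, two measured steps bear on this: replacing 3-(trifluoromethyl)phenyl by 4-(trifluoromethyl)phenyl gave a 1.5-fold lower number from compound 1 to compound 3 (0.17 log units; within the scatter), and replacing 2-chlorophenyl by 4-(trifluoromethyl)phenyl gave a 3.4-fold lower number from compound 2 to compound 3 (0.53 log units; beyond the scatter). Compound 4 combines features of compound 1 and compound 2, so a modest rise in the number, near the edge of the scatter, is expected. Compound 4 is therefore estimated at 2100 nM, with a range from 900 nM to 4800 nM, which would mean a step of a 1.6-fold higher number from compound 3 to compound 4 (0.21 log units; within the scatter).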

Compound 4, half-maximal inhibitory concentration: 1450 nM
Compound 4: the middle estimate sits 1.4-fold (0.16 log units) above what was measured, within the range that was stated.
By their numbers in this assay, from the lowest: compounds 3, 4 and 1 (each within the scatter of the next); then compound 2.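

In this assay, 3-chlorophenyl on the amine nitrogen in the ring serves as well as 4-(trifluoromethyl)phenyl (a 1.1-fold higher number from compound 3 to compound 4 (0.05 log units; within the scatter)), and chloro serves as well as trifluoromethyl on the same aromatic carbon (a 1.3-fold lower number from compound 1 to compound 4 (0.13 log units; within the scatter)). Replacing 2-chlorophenyl by 3-chlorophenyl gives a change beyond the scatter (a 3.0-fold lower number from compound 2 to compound 4 (0.48 log units; beyond the scatter)), so the high number of compound 2 goes with 2-chlorophenyl and not with chloro as such. From the compounds shown here alone, how a methoxy group or an amine would fare in place of chloro on that aromatic carbon stays open. No evidence is available to explain these differences.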